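This account rests on a few compounds, and the source may have more. Where it says the series, first, only, none or still open, it means among the compounds named here.

Measured so far:
compound 1, `Oc1cccc(-c2cc(-c3ccccc3)nc(-c3ccc(Cl)cc3)c2)c1` — 7.1%
compound 2, `Oc1cccc(-c2cc(-c3ccccn3)nc(-c3ccccc3Cl)c2)c1` — 0%

In an assay on isolated protein for inhibition of DNA topoisomerase 1 (Homo sapiens), with a stated time of 30 min, tested at 100 uM (a higher number here means a stronger effect of the compound at the concentration tested, a lower number a weaker effect), compound 1 gives 7.1%. In this assay compound 2 gives 0%, the smaller of the two numbers, but the gap to compound 1 lies within the usual scatter of such measurements, so the two compounds cannot be told apart on these data.

Compound 3, `Oc1cccc(-c2cc(-c3ccccc3)nc(-c3ccccc3Cl)c2)c1`, has not been measured. It differs from compound 2 in one place: phenyl in place of pyridin-2-yl on an aromatic carbon. Compound 1 carries the same phenyl group and gives a number close to that of compound 2, so there is no indication that this change moves the read-out; the step is expected to be none beyond the scatter, in either direction.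

The estimated step of a number 4 percentage points higher from compound 2 to compound 3 (within the scatter) rests on this. Compound 3 is expected to give about 4%, within a range of 0% to 15%.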

Compound 3, a percentage reported as inhibition, at one concentration (the size of the read-out at that concentration, not a potency): 3.2%
For compound 3 the middle estimate is 0.8 percentage points above the measured one, and the stated range covers the measured number.
By their numbers in this assay, from the lowest: compounds 2, 3 and 1 (each within the scatter of the next).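

In this assay, phenyl in place of pyridin-2-yl on this aromatic carbon, next to the ring nitrogen, gives a number 3.2 percentage points higher from compound 2 to compound 3 (within the scatter), so this direct comparison shows no readable effect of exchanging these two rings at this position. The same compound also gives a second one-place comparison: 2-chlorophenyl in place of 4-chlorophenyl gives a number 3.9 percentage points lower from compound 1 to compound 3 (within the scatter), so these two chlorophenyl groups cannot be told apart here either. No independent measurement is available to explain either result.

The compounds shown leave open whether any other group on this carbon, such as an amine, a carboxylic acid or a longer chain, would give a step beyond the scatter. They also leave open whether a methoxy group in place of the hydroxyl of the 3-hydroxyphenyl group would change the read-out.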